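Hydrogen in place of 5-chloropyridin-2-yl: compound 3

The source may hold more compounds than are shown below. What is called first, only, known or untested is meant among the compounds shown, and "the series" means these compounds.

In a physicochemical assay for lipophilicity, read by HPLC, at pH 7.4 (a lower number here means a more polar compound, a higher number a more lipophilic compound), compound 2 (`C[C@@H](Oc1cc2oc(=O)n(CCC(=O)O)c2cc1Cl)c1ccc(Cl)cn1`) stands highest of the two measured compounds at 2.65 against compound 1 (`Cc1ccc([C@@H](C)Oc2cc3oc(=O)n(CCC(=O)O)c3cc2Cl)nc1`) at 2.02 on the same scale. The change to compound 3 (`CCOc1cc2oc(=O)n(CCC(=O)O)c2cc1Cl`) is hydrogen in place of 5-chloropyridin-2-yl on a saturated chain carbon bound to an oxygen on an aromatic ring and a saturated chain carbon and removes the whole group carrying that chloro. Among the compounds with values here, the one measured step is a number 0.63 log units higher from compound 1 to compound 2 (beyond the scatter) for chloro in place of methyl on an aromatic carbon, and it covers only part of the departing group. A larger downward move is therefore expected, with the estimated step being a number 1.25 log units lower from compound 2 to compound 3 (beyond the scatter) in this series. For compound 3 the estimate is 1.4 with an expected range of 0.8 to 2 in this assay once measured.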

Compound 3, distribution coefficient: 1.49
Estimate against measurement, compound 3: 0.09 log units below; the measured number falls inside the stated range.
By their numbers in this assay, from the lowest: compound 3; then compound 1; then compound 2.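

In this assay loss of the 5-chloropyridin-2-yl group gives a number 1.16 log units lower from compound 2 to compound 3 (beyond the scatter) and loss of the 5-methylpyridin-2-yl group gives a number 0.53 log units lower from compound 1 to compound 3 (beyond the scatter) so this saturated chain carbon now has a reading with hydrogen in place of either group. Both compounds carrying a six-membered aromatic ring here read higher than compound 3, by an amount that differs with the group on that ring. No measured evidence bears on the reason for these steps.

Open, as far as these compounds go, is where a plain phenyl ring or a longer alkyl chain in place of that hydrogen would read on this scale. Also open, from the compounds shown here alone, is how an amine on the pyridine ring would compare with the chloro and methyl groups.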